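This account rests on a few compounds, and the source may have more. Where it says the series, first, only, none or still open, it means among the compounds named here.

Working notes on the series. Compound 1 `CS(=O)(=O)Nc1ccc2c(c1)S(=O)(=O)N=C(C1=C(O)C3CCCC3N(Cc3ccccn3)C1=O)N2` was measured in an ADME assay on microsomes from liver (Homo sapiens) for metabolic stability, with a stated time of 60 min, tested at 1 uM (a higher number here means that more of the compound is left, a lower number that less of the compound is left), and gives 76%. Compound 2 `Cc1cc(CN2C(=O)C(C3=NS(=O)(=O)c4cc(NS(C)(=O)=O)ccc4N3)=C(O)[C@H]3CCC[C@H]32)ccc1F` gives in this assay 66%. Compound 2 and compound 1 lie within the usual scatter of each other, so the two numbers shown do not separate them. Compound 3 `CS(=O)(=O)Nc1ccc2c(c1)S(=O)(=O)N=C(C1=C(O)[C@H]3CCC[C@H]3N(Cc3ccc(F)c(Cl)c3)C1=O)N2` is not yet measured. Compound 3 differs from compound 2 in one place: chloro in place of methyl on an aromatic carbon. Going by the values given here, no step between measured compounds covers this change. The expected step of a number 4 percentage points higher from compound 2 to compound 3 (within the scatter) is small, without a direction beyond the scatter. For compound 3 the estimate in this assay is 70%, with a range from 55% to 85%.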

Compound 3, percent of the compound remaining: 81%
The estimate for compound 3 lay 11 percentage points below the measured number; the measured number falls inside the stated range.
By their numbers in this assay, from the lowest: compounds 2, 1 and 3 (each within the scatter of the next, the first and the last beyond it).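

With the 4-fluoro-3-methylbenzyl group replaced by 3-chloro-4-fluorobenzyl, this assay gives a number 15 percentage points higher from compound 2 to compound 3 (beyond the scatter), so the methyl position ortho to the fluoro group is one where a single-atom change can move the read-out. The earlier compounds shown here offered no step at this position. Nothing available explains the shift.

On these data alone, whether a bromo, methoxy or trifluoromethyl group at this position would behave like chloro remains open. So does whether the step would persist without the fluoro group.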